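This account rests on a few compounds, and the source may have more. Where it says the series, first, only, none or still open, it means among the compounds named here.

Measured compounds:
- compound 1, `Nc1sc(-c2ccccc2)c(-c2ccccc2)c1C(=O)c1ccc(Cl)cc1`: 1%
- compound 2, `CC(C)(C)Cc1c(-c2ccncc2)sc(N)c1C(=O)c1ccc(Cl)cc1`: 6%

In an assay on CHO cells for displacement of a labelled ligand from adenosine receptor A3 (Homo sapiens), read by scintillation counting, tested at 10 uM (on this read-out lower numbers stand for less inhibition and higher numbers for more inhibition at the one concentration tested (going by the name of the read-out)), compound 1 gives 1%, and compound 2 gives 6%. Both numbers sit at the bottom of the scale, and the gap between them stays within the usual scatter of this assay, so the two compounds cannot be told apart on these data. Compound 3, `CC(C)(C)Cc1c(-c2cc(F)ccc2F)sc(N)c1C(=O)c1ccc(Cl)cc1`, has not yet been measured. It differs from compound 2 in one place: 2,5-difluorophenyl in place of pyridin-4-yl on an aromatic carbon. The group leaving is pyridin-4-yl, the group entering is 2,5-difluorophenyl, and the place is an aromatic carbon of the five-membered aromatic ring with one sulfur, next to the ring sulfur. Among the compounds with values here, no measured pair in this set follows such a change, so no step size can be taken from the data. Given that compound 2 shows 6%, compound 3 is expected to stay near that low level, with a step of a number 1 percentage points higher from compound 2 to compound 3 (within the scatter) that is expected to remain within the scatter. The estimate for compound 3 is 7%, with a range from 0% to 25%.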

Compound 3, a percentage reported as inhibition, at one concentration (the size of the read-out at that concentration, not a potency): 1%
The estimate for compound 3 lay 6 percentage points above the measured number; low and high end bracket the measured number.
By their numbers in this assay, from the lowest: compounds 1, 3 and 2 (each within the scatter of the next).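

Within the data shown here, putting 2,5-difluorophenyl in place of pyridin-4-yl on this aromatic carbon, next to the ring sulfur, gives a number 5 percentage points lower from compound 2 to compound 3 (within the scatter) in this assay and provides the first step that can be read at this position. The entering ring has carbon only and carries two fluorines, while the leaving ring has one nitrogen, yet the two compounds cannot be told apart. At this low level, this one exchange of aromatic rings does not lift the number off the bottom of the scale.

On these data alone, whether an aminomethyl group or a carboxylic acid on this carbon would give a clearer signal stays open, as does the effect of replacing the neopentyl group with a longer chain. Nothing measured here gives a reason for these low numbers.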